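The source may hold more compounds than are shown below. What is called first, only, known or untested is meant among the compounds shown, and "the series" means these compounds.

In an ADME assay on MT4 cells (Homo sapiens) for cytotoxicity, read by MTT assay (a lower number here means that less compound is tolerated, a higher number that more compound is tolerated), compound 1 `O=C(CSc1nnnn1-c1cccc2ccccc12)N/N=C/c1cccs1` gives only a limit, > 316000 nM, the highest concentration tested (the limit of > 316000 nM in this assay, at which 1 of the 3 values shown sits). Its two measured relatives differ from it at the carbon that carries the double bond to nitrogen. Compound 2 `Cc1cccc(/C=N/NC(=O)CSc2nnnn2-c2cccc3ccccc23)c1` gives 269000 nM in this assay, and compound 3 `COc1ccc(/C=N/NC(=O)CSc2nnnn2-c2cccc3ccccc23)cc1OC` gives 191000 nM. From compound 1 the steps are an at least 1.1-fold lower number from compound 1 to compound 2 (0.06 log units; that floor lies within the scatter) and an at least 1.6-fold lower number from compound 1 to compound 3 (0.21 log units; that floor lies within the scatter), and between the two measured relatives the step is a 1.4-fold lower number from compound 2 to compound 3 (0.15 log units; within the scatter); none of these reaches beyond the scatter of the method. Compound 4 `O=C(CSc1nnnn1-c1cccc2ccccc12)N/N=C/c1cccc(O)c1` changes compound 1 at the same place: 3-hydroxyphenyl in place of thiophen-2-yl on a carbon with a double bond to nitrogen. The two measured steps from compound 1 are the ones that bear on this change, and both are small, so no step beyond the scatter is expected in this assay. The step expected is an at least 1.2-fold lower number from compound 1 to compound 4 (0.10 log units; that floor lies within the scatter). Compound 4 is therefore estimated at 250000 nM, in a range from 130000 nM to 400000 nM, with a real chance that only a limit is reported again.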

Compound 4, half-maximal cytotoxic concentration: 169000 nM
For compound 4 the middle estimate is 1.5-fold (0.17 log units) above the measured one; the range from low to high includes it.
By their numbers in this assay, from the lowest: compounds 4, 3 and 2 (each within the scatter of the next). At a limit, above all of these: compound 1.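

The 3-hydroxyphenyl group brings a hydrogen-bond donor to this carbon, where thiophen-2-yl has none, and in this assay this change gives an at least 1.8-fold lower number from compound 1 to compound 4 (0.27 log units; that floor lies within the scatter). Among the measured aromatic groups, hydroxy in place of methyl on an aromatic carbon gives a 1.6-fold lower number from compound 2 to compound 4 (0.20 log units; within the scatter), and 3-hydroxyphenyl in place of 3,4-dimethoxyphenyl gives a 1.1-fold lower number from compound 3 to compound 4 (0.05 log units; within the scatter). So this position has now taken a thiophene ring and three differently substituted phenyl rings, including one with a hydroxy group, without any step that can be told from the scatter.

On these data alone, compound 1 still gives only a limit, so its step has a floor and no exact size: the limit of > 316000 nM in this assay, at which 1 of the 4 values shown sits. Whether an amine or a carboxylic acid on the phenyl ring, or a longer chain at this carbon, would give a step beyond the scatter stays open.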